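Ethynyl in Place of Phenyl: Expecting Compound 4

A few compounds are considered here, and "the series" means these few. Any claim that something is new, unique, unknown or untested is made for them only; others in the source may bear on it.

Compound 1, `Cc1nc(N)c2c(-c3ccccc3)cn([C@@H]3O[C@H](CO)[C@@H](O)[C@H]3O)c2n1`, reaches only the limit of > 20000 nM in a functional assay on HeLa S3 cells (Homo sapiens) for antiproliferative activity, read by XTT assay, with a stated time of 72 h; a higher number here means a weaker inhibitor, a lower number a stronger inhibitor.
Compound 2, `C#Cc1cn([C@@H]2O[C@H](CO)[C@@H](O)[C@H]2O)c2nc(C)nc(N)c12`, likewise reaches only the limit of > 20000 nM in this assay.
Compound 3, `COc1ncnc2c1c(-c1ccccc1)cn2[C@@H]1O[C@H](CO)[C@@H](O)[C@H]1O`, also reaches only the limit of > 20000 nM in this assay.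

Compound 1 and compound 2 differ in one place: ethynyl in place of phenyl on an aromatic carbon. The step that the two limits leave unreadable from compound 1 to compound 2 cannot be sized, because both values sit at the limit of > 20000 nM in this assay, at which 3 of the 3 values shown sit. Compound 3 carries a different core from compound 1; how the two cores differ is not broken down here. Compound 4, `C#Cc1cn([C@@H]2O[C@H](CO)[C@@H](O)[C@H]2O)c2ncnc(OC)c12`, the compound not yet measured, differs from compound 3 by ethynyl in place of phenyl on an aromatic carbon, the same change made from compound 1 to compound 2, at the same place. Among the measured compounds shown here, the only precedent for this change gave no readable step, and compound 3 itself starts at a limit, so no movement into the measurable range is expected. Compound 4 is therefore expected at about 30000 nM in this assay, with the step that the limit leaves unreadable from compound 3 to compound 4 expected to be essentially none and the likeliest outcome another limit.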

Compound 4, half-maximal inhibitory concentration: 1730 nM
For compound 4 the middle estimate is 17-fold (1.24 log units) above the measured one, and the stated range ends above it.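

On the core of compound 3, ethynyl in place of phenyl on an aromatic carbon gives an at least 11-fold lower number from compound 3 to compound 4 (1.06 log units; beyond the scatter) in this assay, which takes the series from a limit to a measured number. On the core of compound 1 the same change gives a step that cannot be read, and compound 2 remains at a limit, so the change does not yield a measured value on both cores: the limit of > 20000 nM in this assay, at which 3 of the 4 values shown sit. This shows that a precedent stuck at a limit says little about what the change does on another core, but it does not show how large the change is on the core of compound 1, what in the two cores separates the outcomes, or that one readable step makes a pattern.

The compounds shown leave open whether this result is particular to ethynyl. A nitrile, a bromine atom or a longer alkyne chain such as propynyl on the same aromatic carbon could tell that apart.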